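Cytotoxicity series: hydrogen for 4-methoxybenzyl on the aromatic nitrogen

This account rests on a few compounds, and the source may have more. Where it says the series, first, only, none or still open, it means among the compounds named here.

Measured so far in a functional assay on PC-3 cells (Homo sapiens) for cytotoxicity, read by WST assay, with a stated time of 24 h; a lower number here means a stronger inhibitor, a higher number a weaker inhibitor:
- compound 1 `COc1ccc(Cn2cc(/C=C(\C#N)C(=O)c3c[nH]c4cc(OC)ccc34)c3ccccc32)cc1`: > 50000 nM, a limit of the assay, not a number
- compound 2 `COc1ccc2c(C(=O)/C(C#N)=C/c3c[nH]c4ccc(OC)cc34)c[nH]c2c1`: 31100 nM
- compound 3 `N#C/C(=C\c1c[nH]c2ccccc12)C(=O)c1c[nH]c2ccccc12`: > 50000 nM, again a limit of the assay

Compound 1 stands only at a limit in this assay. Of the two further values, compound 3 also sits at a limit, and only compound 2 gives a number, itself a weak one. Within the data shown here, no two measured compounds differ in a single place, so no measured step is available to guide the next change.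

Compound 4 `COc1ccc2c(C(=O)/C(C#N)=C/c3c[nH]c4ccccc34)c[nH]c2c1` differs from compound 1 by hydrogen in place of 4-methoxybenzyl on an aromatic nitrogen. Among the measured compounds shown here, with no measured step of this kind, the expectation rests on the weak level of the whole set: the step from compound 1 to compound 4 an at least 1.4-fold lower number from compound 1 to compound 4 (0.15 log units; that floor lies within the scatter) is expected to be small, at most a modest move toward a measurable number, and may well lie within the scatter. Compound 4 is therefore expected to give about 35000 nM in this assay, within 12000 nM to 100000 nM. A report of a limit rather than a number remains quite likely for compound 4, because of the limit of > 50000 nM in this assay, at which 2 of the 3 values shown sit.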

Compound 4, half-maximal inhibitory concentration: > 50000 nM
Compound 4 ended at the assay's limit; the forecaster's own chance of this, stated with the estimate: 50%; middle value at least 1.4-fold (0.15 log units) away from the limit.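

Hydrogen in place of 4-methoxybenzyl on the aromatic nitrogen does not bring this core to a measurable number in this assay, so this position has as yet shown no readable effect. The steps joining compound 4 to compound 1 and to compound 3 cannot be read, and the set now leans further toward the limit: the limit of > 50000 nM in this assay, at which 3 of the 4 values shown sit. The one readable step is an at least 1.6-fold higher number from compound 2 to compound 4 (0.20 log units; that floor lies within the scatter), for hydrogen in place of methoxy on an aromatic carbon, so the measurable value of compound 2 is not shown to depend on that methoxy, although the true size of the step may be larger than its floor.

From the compounds shown here alone, whether any group on the aromatic nitrogen changes the reading stays open, as compound 1 and compound 4 both rest at limits of the assay. Also open, going by these compounds, is whether a methyl group, or a longer chain carrying an amine, at that aromatic nitrogen would give a number in this assay at all.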